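Moving the methyl group around the anilino ring

A few compounds are considered here, and "the series" means these few. Any claim that something is new, unique, unknown or untested is made for them only; others in the source may bear on it.

Of the compounds shown here, three sharing one core have been measured in a functional assay on MCF7 cells (Homo sapiens) for inhibition, read by MTT assay, with a stated time of 72 h; a higher number here means a weaker inhibitor, a lower number a stronger inhibitor. Compound 1 `Cc1cccc(Nc2nc(SCc3cn(Cc4ccccc4Cl)nn3)nc(-c3ccccc3)c2C#N)c1` gives 19600 nM. Compound 2 `N#Cc1c(Nc2cccc([N+](=O)[O-])c2)nc(SCc2cn(Cc3ccccc3Cl)nn2)nc1-c1ccccc1` gives > 64000 nM, which is a limit of the assay rather than a number (the limit of > 64000 nM in this assay, at which 1 of the 3 values shown sits). Compound 3 `Cc1ccccc1Nc1nc(SCc2cn(Cc3ccccc3Cl)nn2)nc(-c2ccccc2)c1C#N` gives 7950 nM, the lowest number among the two measured values, with compound 1 nearest to it. The step of an at least 3.2-fold higher number from compound 1 to compound 2 (0.51 log units; beyond the scatter) and the step of an at least 8.0-fold lower number from compound 2 to compound 3 (0.90 log units; beyond the scatter) both move away from the nitro-bearing compound 2, while the step of a 2.5-fold lower number from compound 1 to compound 3 (0.39 log units; beyond the scatter) shows a modest gain on moving the methyl group from 3-methylphenyl to 2-methylphenyl.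

Compound 4 `Cc1ccc(Nc2nc(SCc3cn(Cc4ccccc4Cl)nn3)nc(-c3ccccc3)c2C#N)cc1` has not yet been measured. Its change from compound 3 is 4-methylphenyl in place of 2-methylphenyl on a nitrogen on an aromatic ring. Among the measured compounds shown here, only the step of a 2.5-fold lower number from compound 1 to compound 3 (0.39 log units; beyond the scatter) bears on this, and it shows that where the methyl group sits on this ring matters by a modest amount. For the measured compounds named here, no measured step covers the 4-methylphenyl group itself, so compound 4 is expected to fall somewhere between compound 3 and compound 1, with a modest rise from compound 3 as the likelier outcome: a 1.8-fold higher number from compound 3 to compound 4 (0.25 log units; within the scatter). Compound 4 is therefore estimated at 14000 nM in this assay, within a range from 6000 nM to 40000 nM.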

Compound 4, half-maximal inhibitory concentration: 9420 nM
Beside the measured number, compound 4's estimate is 1.5-fold (0.17 log units) above it; low and high end bracket the measured number.
By their numbers in this assay, from the lowest: compounds 3 and 4 (each within the scatter of the next); then compound 1. At a limit, above all of these: compound 2.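

In this assay, the new result shows that moving the methyl group around the anilino ring does not give a steady trend: a 1.2-fold higher number from compound 3 to compound 4 (0.07 log units; within the scatter) stays within the scatter, so 4-methylphenyl and 2-methylphenyl on this nitrogen cannot be told apart. By contrast, a 2.1-fold lower number from compound 1 to compound 4 (0.32 log units; beyond the scatter) lies beyond the scatter, which leaves the 3-methylphenyl of compound 1 as the one methyl placement that stands apart, with the higher number. The nitro comparison also now has a second methyl partner, an at least 6.7-fold lower number from compound 2 to compound 4 (0.83 log units; beyond the scatter), and the value of compound 2 in that step is a limit and not a number: the limit of > 64000 nM in this assay, at which 1 of the 4 values shown sits.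

The compounds shown leave open whether this pattern belongs to the methyl group alone or would also appear with a methoxy group, a chlorine or an amine on the anilino ring, since the only other group here is the nitro of compound 2. They also leave open how much of the remaining activity depends on the anilino ring at all, as a plain amino group on the shared core does not appear among them.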